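Removing a Ring Chlorine from Compound 2

The source may report more compounds than this note shows. Statements on the series, on what has been measured and on what is new or still open speak of the compounds shown alone.

Compound 1 `FC(F)=C(F)CCSc1nc2ccccc2s1` and compound 2 `FC(F)(Cl)C(F)(Cl)CCSc1nc2ccc(Cl)cc2s1` share the same core and differ in the chain and in a ring substituent. In a functional assay on MCF7 cells (Homo sapiens) for cytotoxicity, read by MTT assay, with a stated time of 48 h (on this read-out higher numbers stand for weaker inhibition and lower numbers for stronger inhibition), compound 1 gives only an assay limit, > 120000 nM. In this assay compound 2 likewise gives only a limit, > 120000 nM. Compound 2 thus stands at the ceiling of the numbers shown, where both values sit (the limit of > 120000 nM in this assay, at which 2 of the 2 values shown sit). Compound 3 `FC(F)(Cl)C(F)(Cl)CCSc1nc2ccccc2s1` differs from compound 2 by hydrogen in place of chloro on an aromatic carbon. Within the data shown here, no measured step covers this change, so in this assay no shift beyond the scatter is expected. The step that the limit leaves unreadable from compound 2 to compound 3 is expected to stay within scatter. Compound 3 is estimated at 150000 nM, between 60000 nM and 400000 nM.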

Compound 3, half-maximal inhibitory concentration: > 120000 nM
Compound 3: no number, only a limit; the forecaster's own chance of this, stated with the estimate: 80%; the middle value lies beyond the limit too.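

In this assay compound 3 gives > 120000 nM, which is a limit and not a number. Compound 2 also gives only a limit, so no step can be read between compound 2 and compound 3. The compounds shown leave open whether hydrogen in place of chloro on an aromatic carbon changes cytotoxicity at all.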